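Compound 3 to compound 4: a benzofuran swap

The source may hold more compounds than are shown below. What is called first, only, known or untested is meant among the compounds shown, and "the series" means these compounds.

Values in a functional assay on HepG2 cells (Homo sapiens) for antiproliferative activity, read by XTT assay, with a stated time of 72 h (a higher number here means a weaker inhibitor, a lower number a stronger inhibitor), are as follows
- compound 1 `CN(C)c1ncnc2c1c(-c1cc3ccccc3o1)cn2[C@@H]1O[C@H](CO)[C@@H](O)[C@H]1O` gives > 20000 nM as a limit
- compound 2 `Cc1ncnc2c1c(-c1cccs1)cn2[C@@H]1O[C@H](CO)[C@@H](O)[C@H]1O` gives > 15000 nM as a limit
- compound 3 `Cc1ncnc2c1c(-c1ccsc1)cn2[C@@H]1O[C@H](CO)[C@@H](O)[C@H]1O` gives 4720 nM as a number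

Within the data shown here, compound 3 at 4720 nM holds the only true number in the set. The other two entries are limits. Compound 4 `Cc1ncnc2c1c(-c1cc3ccccc3o1)cn2[C@@H]1O[C@H](CO)[C@@H](O)[C@H]1O` has not yet been measured. The change from compound 3 is 1-benzofuran-2-yl in place of thiophen-3-yl on an aromatic carbon on the shared core, that is, 1-benzofuran-2-yl in place of thiophen-3-yl on an aromatic carbon.

Two observations bear on this change. The step of an at least 3.1-fold lower number from compound 2 to compound 3 (0.50 log units; beyond the scatter) is the only measured one and shows that the choice of group at this carbon can move the result beyond the scatter. Compound 1 already carries 1-benzofuran-2-yl, on a core that differs elsewhere, and it reads > 20000 nM as a limit.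

A move to a higher number is therefore expected in this assay, of modest size, with a real chance that only a limit is reported. The expected step is a 2.5-fold higher number from compound 3 to compound 4 (0.41 log units; beyond the scatter) in this estimate. For compound 4 the estimated value is 12000 nM with an expected range from 4000 nM to 30000 nM in this assay.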

Compound 4, half-maximal inhibitory concentration: > 20000 nM
Compound 4: a limit, no number; the forecaster's own chance of this, stated with the estimate: 55%; middle value at least 1.6-fold (0.22 log units) away from the limit.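

In this assay, the change to 1-benzofuran-2-yl on the aromatic carbon of the shared core gives an at least 4.2-fold higher number from compound 3 to compound 4 (0.62 log units; beyond the scatter), and this is a minimum size only, compound 4 being read as a limit. The earlier step showed only that moving from thiophen-2-yl to thiophen-3-yl matters at this carbon; this step shows that adding a six-membered aromatic ring to a five-membered aromatic ring with one hetero atom also moves the result beyond the scatter, in the direction of a weaker inhibitor. Among the compounds shown with methyl on the shared core, compound 3 with thiophen-3-yl remains the only one with a true number, while compound 4 shares its limit with compound 1: the limit of > 20000 nM in this assay, at which 2 of the 4 values shown sit.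

The steps to compound 4 from compound 2 and from compound 1 cannot be read, so neither the change from thiophen-2-yl nor the change from dimethylamino to methyl has a size here. Open too, on these data alone, is whether a phenyl or furan-3-yl group at this carbon, or a thiophen-3-yl group carrying an amine or a carboxylic acid, would give a lower number than compound 3.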